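Replacing a Pyrazole with an Oxazole on a Silent Core

The source may report more compounds than this note shows. Statements on the series, on what has been measured and on what is new or still open speak of the compounds shown alone.

Measured compounds:
Compound 1, `Cn1ccc(-c2cccc3c2CCC3c2ncc[nH]2)n1`: > 10000 nM
Compound 2, `CS(=O)(=O)Nc1c(Cl)ccc2c1CCCC2c1ncc[nH]1`: > 10000 nM
Compound 3, `Clc1ccc2c(c1-c1ccn[nH]1)CCC2c1ncc[nH]1`: > 10000 nM

Compound 1 carries a 1-methyl-1H-pyrazol-3-yl group on its core. In a functional assay on CHO cells for agonist activity at Alpha-1D adrenergic receptor (Homo sapiens), read by FLIPR and calcium flux (on this read-out higher numbers stand for an effect only at larger amounts of compound and lower numbers for an effect already at smaller amounts), compound 1 gives > 10000 nM, which is a limit of the assay and not a measured number. Compound 2 likewise reaches only a limit in this assay. Compound 3 also sits at a limit in this assay. For the measured compounds named here, because of the limit of > 10000 nM in this assay, at which 3 of the 3 values shown sit, compound 1 cannot be placed above or below its two neighbours; all three show no effect up to the highest amount tested, and no step between any pair of them can be sized.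

Compound 4, `c1cc(-c2ncco2)c2c(c1)C(c1ncc[nH]1)CC2`, has not been measured. It differs from compound 1 in one place: 1,3-oxazol-2-yl in place of 1-methyl-1H-pyrazol-3-yl on an aromatic carbon. Since compound 1 gives only a limit, the step in this assay is expected to be none beyond the scatter, the change from compound 1 to compound 4 being estimated at a step that the limit leaves unreadable from compound 1 to compound 4, with compound 4 most likely remaining at a limit. Compound 4 is therefore expected to give roughly 20000 nM in this assay, with a range from 5000 nM to 100000 nM.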

Compound 4, half-maximal effective concentration: 1390 nM
Compound 4: the middle estimate sits 14-fold (1.16 log units) above what was measured, and the stated range ends above it.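

For the compounds shown here, putting 1,3-oxazol-2-yl in place of 1-methyl-1H-pyrazol-3-yl gives an at least 7.1-fold lower number from compound 1 to compound 4 (0.85 log units; beyond the scatter) in this assay, so this place on the aromatic carbon can respond to the group it carries, which the earlier compounds could not show. The two groups match in much of what is counted, each being one five-membered aromatic ring with 2 hetero atoms, 0 hydrogen-bond donors and 2 hydrogen-bond acceptors, so these counts alone do not separate a silent compound from an active one. The full size of the step cannot be read because compound 1 sits at a limit: the limit of > 10000 nM in this assay, at which 3 of the 4 values shown sit.

The compounds shown cannot tell whether the ring oxygen or the loss of the methyl group matters more. As far as these compounds go, how a 1,3-thiazol-2-yl group, an amide or a simple amine would read at this place also remains open.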